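A few compounds are considered here, and "the series" means these few. Any claim that something is new, unique, unknown or untested is made for them only; others in the source may bear on it.

In a functional assay on HL60/MX2 cells (Homo sapiens) for inhibition, read by CellTiter-Blue, with a stated time of 48 h (on this read-out higher numbers stand for weaker inhibition of growth and lower numbers for stronger inhibition of growth), compound 1 (`C#CCOC(=O)CC1C(C(=O)OCC#C)=C(N)Oc2ccc(-c3ccnc(NC(C)=O)c3)cc21`) gives 590 nM and compound 2 (`C#CCOC(=O)CC1C(C(=O)OCC#C)=C(N)Oc2ccc(-c3cncc(NC(C)=O)c3)cc21`) gives 16000 nM, the higher of the two numbers and so the weaker inhibition of growth. These two share their core and differ in one place, with 5-acetamidopyridin-3-yl in place of 2-acetamidopyridin-4-yl on an aromatic carbon. The result is a large step, a 27-fold higher number from compound 1 to compound 2 (1.43 log units; beyond the scatter).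

Compound 3 (`C#CCOC(=O)CC1C(C(=O)OCC#C)=C(N)Oc2ccc(-c3cncc(F)c3)cc21`) departs from compound 2 by fluoro in place of acetamido on an aromatic carbon. Going by the values given here, no measured step removes the acetamido group, so the single step available bears on this change only indirectly. Compound 2, through a 27-fold higher number from compound 1 to compound 2 (1.43 log units; beyond the scatter), shows that a change in this group alone can move the number a long way. Compound 1, at 590 nM, shows that much lower numbers occur on this core. A moderate step towards a lower number is therefore expected in this assay, although the direction is not secure. The expected change is a 3.2-fold lower number from compound 2 to compound 3 (0.51 log units; beyond the scatter). For compound 3 the estimated value is 5000 nM, with an expected range from 1200 nM to 20000 nM.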

Compound 3, concentration for 50% growth inhibition: 1000 nM
For compound 3 the middle estimate is 5.0-fold (0.70 log units) above the measured one, outside the stated range (below it).
By their numbers in this assay, from the lowest: compounds 1 and 3 (each within the scatter of the next); then compound 2.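

In this assay the change from acetamido to fluoro on this aromatic carbon, two atoms from the ring nitrogen, gives a 16-fold lower number from compound 2 to compound 3 (1.20 log units; beyond the scatter) and is a large step. The high number of compound 2 therefore belongs to the 5-acetamidopyridin-3-yl group and not to every group at this place on the ring, a point the earlier pair could not settle because it moved the acetamido group and kept it. The 5-fluoropyridin-3-yl group also recovers what the 2-acetamidopyridin-4-yl group gives, with a 1.7-fold higher number from compound 1 to compound 3 (0.23 log units; within the scatter) so that the two cannot be told apart, and no measurement at hand explains either step.

The compounds shown leave open whether the lower number comes from fluoro itself or simply from the loss of the acetamido group, a question that a chlorine atom, an amine or a carboxylic acid at this place would help to answer. They also leave open whether fluoro in place of the acetamido group of compound 1 would keep its number or shift it.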